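Truncating the hydrazone arm of compound 1

The source may hold more compounds than are shown below. What is called first, only, known or untested is meant among the compounds shown, and "the series" means these compounds.

Going by the values given here, compound 1 `C/C(=N\Nc1nc2ccccc2nc1Cc1ccccc1)c1ccccc1` stands at the high end of the two numbers so far: in an assay on isolated protein for inhibition of Amine oxidase [flavin-containing] A (Homo sapiens), read by spectrophotometry (a lower number here means a stronger inhibitor, a higher number a weaker inhibitor), compound 1 gives 79 nM, while compound 2 `C/C(=N\Nc1nc2ccccc2nc1Cc1ccccc1)c1ccc(N)cc1` gives 9.8 nM. Among the compounds with values here, the one measured step between them is an 8.1-fold lower number from compound 1 to compound 2 (0.91 log units; beyond the scatter), an amino group on an aromatic carbon. Compound 3 `C=NNc1nc2ccccc2nc1Cc1ccccc1` differs from compound 1 by a group of 2 heavy atoms (1 carbon, 1 nitrogen; no ring) in place of a group of 9 heavy atoms (8 carbon, 1 nitrogen; one six-membered aromatic ring of carbon only), on a nitrogen on an aromatic ring. Within the data shown here, no measured step touches this part of the molecule; the step from compound 1 to compound 2 alters a different group and offers no direct guide to size or direction here. Since the change removes a six-membered aromatic ring of carbon and leaves only a two-atom group, a weaker inhibitor is expected, likely beyond the scatter, though with wide uncertainty. The step is estimated as a 7.6-fold higher number from compound 1 to compound 3 (0.88 log units; beyond the scatter). Compound 3 is therefore expected to give about 600 nM, in the range 120 nM to 3000 nM.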

Compound 3, half-maximal inhibitory concentration: 86 nM
Beside the measured number, compound 3's estimate is 7.0-fold (0.84 log units) above it; the whole stated range lies above it.
By their numbers in this assay, from the lowest: compound 2; then compounds 1 and 3 (each within the scatter of the next).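

In this assay the change on a nitrogen on an aromatic ring gives a 1.1-fold higher number from compound 1 to compound 3 (0.04 log units; within the scatter), so a group of 9 heavy atoms with one six-membered aromatic ring of carbon only can be replaced by a group of 2 heavy atoms with no ring without a change beyond the scatter. The unsubstituted aromatic ring of compound 1 therefore adds nothing measurable here, whereas the same ring with an amino group gives an 8.1-fold lower number from compound 1 to compound 2 (0.91 log units; beyond the scatter), so this ring matters in this series only once substituted, on the compounds shown. No evidence bearing on the reason for this result is available.

Still open, from the compounds shown here alone, is whether a butyl chain in this place would also leave the number within the scatter. Also open, going by these compounds, is whether a hydroxyl group or a carboxylic acid on the aromatic ring would match the amino group.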